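The source may hold more compounds than are shown below. What is called first, only, known or untested is meant among the compounds shown, and "the series" means these compounds.

Three compounds sharing one core show how much the group on the benzylic carbon matters. In a functional assay on CCRF-CEM cells (Homo sapiens) for antiproliferative activity, with a stated time of 72 h (on this read-out lower numbers stand for stronger inhibition and higher numbers for weaker inhibition), compound 1 (`OC[C@H]1O[C@@H](n2cnc3c(NCc4ccccc4Br)ncnc32)[C@H](O)[C@@H]1O`) gives 12300 nM and compound 2 (`OC[C@H]1O[C@@H](n2cnc3c(NCc4cccc(Br)c4)ncnc32)[C@H](O)[C@@H]1O`) gives 5000 nM. Exchanging one bromophenyl group for the other, a 2.5-fold lower number from compound 1 to compound 2 (0.39 log units; beyond the scatter), is only a modest step.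

Compound 3 (`Cc1ccc(CNc2ncnc3c2ncn3[C@@H]2O[C@H](CO)[C@@H](O)[C@H]2O)cc1`) has a 4-methylphenyl group, and its > 166000 nM is a limit of the assay and not a number. It therefore stands at the weak end of the three.

Compound 4 (`OC[C@H]1O[C@@H](n2cnc3c(NCc4ccc(Cl)cc4Cl)ncnc32)[C@H](O)[C@@H]1O`) has not been measured yet. It differs from compound 3 by one change: 2,4-dichlorophenyl in place of 4-methylphenyl on a saturated chain carbon bound to a nitrogen on an aromatic ring. Here 2,4-dichlorophenyl replaces 4-methylphenyl on the same saturated chain carbon bound to a nitrogen on an aromatic ring.

Within the data shown here, the steps that bear on this change are the two that leave compound 3 from a halogen-bearing ring: an at least 13-fold higher number from compound 1 to compound 3 (1.13 log units; beyond the scatter) and an at least 33-fold higher number from compound 2 to compound 3 (1.52 log units; beyond the scatter). Both are large. Read in reverse, they suggest that compound 4, also halogen-bearing, should land near compound 1 and compound 2, although a chlorine pair has not been tested here.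

A large step to a lower number is therefore expected, estimated as an at least 16-fold lower number from compound 3 to compound 4 (1.22 log units; beyond the scatter).

For compound 4 the expected value is 10000 nM, with an estimated range from 2500 nM to 60000 nM.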

Compound 4, half-maximal inhibitory concentration: 86700 nM
Compound 4: middle estimate off by 8.7-fold (0.94 log units), on the low side; measured number above the stated range.
By their numbers in this assay, from the lowest: compound 2; then compound 1; then compound 4. At a limit, above all of these: compound 3.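

A halogen on the ring is not enough to reach the lower numbers of the bromophenyl compounds: with 2,4-dichlorophenyl on this saturated chain carbon the result is a 17-fold higher number from compound 2 to compound 4 (1.24 log units; beyond the scatter), and likewise a 7.0-fold higher number from compound 1 to compound 4 (0.85 log units; beyond the scatter). Against 4-methylphenyl the same change gives an at least 1.9-fold lower number from compound 3 to compound 4 (0.28 log units; that floor lies within the scatter), which is only a floor for the step and does not establish a real gain. Going by these compounds, the value of compound 3 is a limit and not a number, so the true size of this step stays unknown, because that compound sits at the limit: the limit of > 166000 nM in this assay, at which 1 of the 4 values shown sits.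

The compounds shown do not tell whether the higher number of compound 4 goes with chlorine in place of bromine, with two halogens in place of one, or with where they sit on the ring, since all of these change at once. Also open, on these data alone, is how the number would move with an amine or a carboxylic acid on this ring, or with a longer chain carrying the ring on the same nitrogen.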